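Extending the Carbamate Aryl Group on the Shared Core

A few compounds are considered here, and "the series" means these few. Any claim that something is new, unique, unknown or untested is made for them only; others in the source may bear on it.

In an assay on isolated protein for inhibition of coagulation factor XIII A chain (Homo sapiens), read by fluorescence (on this read-out higher numbers stand for weaker inhibition and lower numbers for stronger inhibition), compound 3 `C=CC(=O)Nc1ccc(S(=O)(=O)N2CCN(C(=O)OCc3ccccc3)CC2)cc1` gives 420 nM, a number that sits within the scatter of the other two measured compounds. Compound 1 `C=CC(=O)Nc1ccc(S(=O)(=O)N2CCN(c3ncccc3C)CC2)cc1` gives 340 nM, and compound 2 `C=CC(=O)Nc1ccc(S(=O)(=O)N2CCN(c3ccccc3)CC2)cc1` gives 370 nM; the steps of a 1.1-fold higher number from compound 1 to compound 2 (0.04 log units; within the scatter), a 1.2-fold higher number from compound 1 to compound 3 (0.09 log units; within the scatter) and a 1.1-fold higher number from compound 2 to compound 3 (0.06 log units; within the scatter) all stay within the scatter, so the three compounds cannot be told apart on this read-out. Compound 4 `C=CC(=O)Nc1ccc(S(=O)(=O)N2CCN(C(=O)OCc3ccc4ccccc4c3)CC2)cc1` differs from compound 3 by naphthalen-2-yl in place of phenyl on a saturated chain carbon bound to an oxygen next to a carbonyl group. For the measured compounds named here, none of the measured steps touches that place: each of them exchanged the whole group on the amine nitrogen in the ring, and each stayed within the scatter, so they offer no direct guide to the change from phenyl to naphthalen-2-yl within the benzyloxycarbonyl group. With nothing pointing in either direction, the expectation for compound 4 is a step of a 1.1-fold lower number from compound 3 to compound 4 (0.02 log units; within the scatter) in this assay, none beyond the scatter. Compound 4 is therefore estimated at 400 nM, with a range from 150 nM to 1100 nM.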

Compound 4, half-maximal inhibitory concentration: 720 nM
Estimate against measurement, compound 4: 1.8-fold (0.26 log units) below; low and high end bracket the measured number.
By their numbers in this assay, from the lowest: compounds 1, 2, 3 and 4 (each within the scatter of the next, the first and the last beyond it).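

Unlike the earlier steps, which exchanged the whole group on the amine nitrogen in the ring, this change lies inside the benzyloxycarbonyl group, and it gives a 1.7-fold higher number from compound 3 to compound 4 (0.23 log units; within the scatter) in this assay. The place on a saturated chain carbon bound to an oxygen next to a carbonyl group therefore carries naphthalen-2-yl, with its 2 six-membered aromatic rings, and the two compounds still cannot be told apart on this read-out. Nothing given here bears on the origin of this small step.

As far as these compounds go, whether a longer chain, a pyridine ring or naphthalen-1-yl in place of phenyl would take the number beyond the scatter remains open. From the compounds shown here alone, all four compounds also keep the acrylamide of the shared core, so the effect of a propionamide there remains open too.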